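Trading an isopropylamino group for a methyl group

The compounds below may be only part of what the source reports. "The series", "measured", "known", "first", "only" and "open" are said of these compounds alone.

In a functional assay on the whole organism for antagonist activity, with Mus musculus as the target (on this read-out higher numbers stand for an effect only at larger amounts of compound and lower numbers for an effect already at smaller amounts), compound 2 `CC(C)NCC(=O)NCC(=O)N(C)c1ccc(Cl)cc1C(=O)c1ccccc1Cl` gives 1 mg/kg, the lowest of three numbers, so it shows its effect at the smallest dose. Compound 3 `NCC(=O)NCC(=O)Nc1ccc([N+](=O)[O-])cc1C(=O)c1ccccc1Cl` gives 2.64 mg/kg and compound 1 `CC(=O)NCC(=O)Nc1ccc(Cl)cc1C(=O)c1ccccc1` gives 37 mg/kg. Both numbers lie above that of compound 2 by more than the usual scatter.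

Compound 4 `CCC(=O)NCC(=O)N(C)c1ccc(Cl)cc1C(=O)c1ccccc1Cl` has not yet been measured. It differs from compound 2 in one place: methyl in place of isopropylamino on a saturated chain carbon bound to a carbonyl carbon. In words, this is methyl in place of isopropylamino on a saturated chain carbon bound to a carbonyl carbon, so the ((isopropylamino)methyl)carbonyl group becomes propanoyl.

Going by the values given here, no measured pair shows this change on its own, so its size must be judged indirectly. Compound 2 and compound 3 both have a free amino group in that chain. Like compound 4, compound 1 has none, and compound 1 gives 37 mg/kg, the highest number in this assay. Compound 1 also differs from compound 4 elsewhere, which makes it only a rough guide. A rise beyond the scatter is therefore expected, an estimated step of a 15-fold higher number from compound 2 to compound 4 (1.18 log units; beyond the scatter). The estimated dose for compound 4 is 15 mg/kg, with an expected range from 4 mg/kg to 60 mg/kg.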

Compound 4, dose for half-maximal effect: 1.4 mg/kg
Compound 4: middle estimate off by 11-fold (1.03 log units), on the high side; the whole stated range lies above it.
By their numbers in this assay, from the lowest: compounds 2, 4 and 3 (each within the scatter of the next, the first and the last beyond it); then compound 1.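

In this assay, going by these compounds alone, the move from the ((isopropylamino)methyl)carbonyl group to propanoyl gives a 1.4-fold higher number from compound 2 to compound 4 (0.15 log units; within the scatter) and is the first direct reading of this change, so on a saturated chain carbon bound to a carbonyl carbon the two groups cannot be told apart. For this pair, the isopropylamino group, with its 4 heavy atoms, 1 hydrogen-bond donor and 1 hydrogen-bond acceptor, can give way to a methyl group with 1 heavy atom and neither donor nor acceptor, without a change beyond the scatter, which means that an amine at this place is not needed for compound 4 to act at a dose level matching that of compound 2. Nothing available here explains why this pair of compounds matches.

Going by these compounds, it remains open whether a carboxylic acid, a longer chain such as butyl, or a ring amine such as piperidine on this same chain carbon would also stay within the scatter of compound 2. On these data alone, it is also open whether the swap from isopropylamino to methyl would read the same way on the core of compound 1 or compound 3, which carry other groups elsewhere.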